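This account rests on a few compounds, and the source may have more. Where it says the series, first, only, none or still open, it means among the compounds named here.

Within the data shown here, compound 1 `COc1nc2ccc(Br)cc2cc1C(c1ccccc1)n1cc(C2CC2)nn1` gives 22.6% in an ADME assay on PC-3 cells (Homo sapiens) for cytotoxicity, read by sulforhodamine B assay, with a stated time of 48 h, tested at 10 uM (on this read-out higher numbers stand for more inhibition at the one concentration tested (going by the name of the read-out) and lower numbers for less inhibition), the highest of the three numbers measured so far. Compound 2 `CCCCCCCc1cn(C(c2ccccc2)c2cc3cc(Br)ccc3nc2OC)nn1` gives 4.42% in this assay, and compound 3 `COc1nc2ccc(Br)cc2cc1C(c1ccccc1)n1cc(CO)nn1` gives 4.65%. Compound 4 `COc1nc2ccc(Br)cc2cc1C(c1ccccc1)n1cc(CCO)nn1` has not been measured; it differs from compound 1 by 2-hydroxyethyl in place of cyclopropyl on an aromatic carbon. Among the measured compounds shown here, two measured steps bear on this change, both of which removed the same cyclopropyl: a number 18.2 percentage points lower from compound 1 to compound 2 (beyond the scatter) and a number 18 percentage points lower from compound 1 to compound 3 (beyond the scatter). Between those two replacements, a number 0.2 percentage points higher from compound 2 to compound 3 (within the scatter), so both ended at much the same low level. For compound 4 a drop of similar size is therefore expected, a number 16.6 percentage points lower from compound 1 to compound 4 (beyond the scatter). Compound 4 is estimated to give 6% in this assay, with a range from 0% to 18%.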

Compound 4, a percentage reported as inhibition, at one concentration (the size of the read-out at that concentration, not a potency): 15.5%
Estimate against measurement, compound 4: 9.5 percentage points below; measured number inside the range.
By their numbers in this assay, from the lowest: compounds 2 and 3 (each within the scatter of the next); then compounds 4 and 1 (each within the scatter of the next).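

At this position in this assay, losing cyclopropyl does not by itself bring the number down: with 2-hydroxyethyl in its place, the result is a number 7.1 percentage points lower from compound 1 to compound 4 (within the scatter). Small differences in the chain count, since hydroxymethyl and 2-hydroxyethyl both carry a hydroxy group yet give a number 10.9 percentage points higher from compound 3 to compound 4 (beyond the scatter), while heptyl gives a number 11.1 percentage points higher from compound 2 to compound 4 (beyond the scatter). No evidence at hand explains these differences.

Still open, as far as these compounds go, is how a 3-hydroxypropyl chain, an aminoethyl group or a carboxylic acid would compare at this position. At these low levels, it is also unclear whether any such group could clearly exceed compound 1.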